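The source may hold more compounds than are shown below. What is called first, only, known or untested is meant among the compounds shown, and "the series" means these compounds.

For the measured compounds named here, in a functional assay on A549 cells (Homo sapiens) for inhibition, read by MTT assay, with a stated time of 72 h (a higher number here means a weaker inhibitor, a lower number a stronger inhibitor), compound 1 `O=C1/C(=C\c2ccccc2)c2c(ncn2COCc2ccccc2)CCN1Cc1ccccc1` gives 9900 nM, the lower of the two numbers measured so far. Compound 2 `O=C1/C(=C\c2ccccc2)c2c(ncn2COCc2ccccc2)CCN1Cc1ccc2ccccc2c1` gives 26400 nM. Naphthalen-2-yl in place of phenyl on a saturated chain carbon accounts for that difference, a 2.7-fold higher number from compound 1 to compound 2 (0.43 log units; beyond the scatter). Compound 3 `O=C1/C(=C\c2ccccc2)c2[nH]cnc2CCN1Cc1ccccc1` has yet to be measured in this assay. It departs from compound 1 at a different place: hydrogen in place of (benzyloxy)methyl on an aromatic nitrogen. Going by the values given here, no measured step touches that nitrogen, so the one step available, a 2.7-fold higher number from compound 1 to compound 2 (0.43 log units; beyond the scatter), gives only a rough idea of how far a single change can move this series. A modest shift towards a higher number is expected, with little certainty about its size or direction. The estimated change is a 2.8-fold higher number from compound 1 to compound 3 (0.45 log units; beyond the scatter). For compound 3 the expected value is 28000 nM, with an estimated range from 8000 nM to 100000 nM.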

Compound 3, half-maximal inhibitory concentration: 51100 nM
Compound 3: the middle estimate sits 1.8-fold (0.26 log units) below what was measured; the measured number falls inside the stated range.
By their numbers in this assay, from the lowest: compound 1; then compounds 2 and 3 (each within the scatter of the next).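

In this assay the exchange of (benzyloxy)methyl for hydrogen gives a 5.2-fold higher number from compound 1 to compound 3 (0.71 log units; beyond the scatter) on the aromatic nitrogen of the five-membered ring. The number therefore responds to this nitrogen as well as to the saturated chain carbon changed in the earlier pair, and of the two compounds compared here, compound 1, which carries (benzyloxy)methyl, has the lower number. No measurement at hand explains this step.

On these data alone, only the whole group and hydrogen are compared, so it remains open whether the six-membered aromatic ring, the oxygen or the chain of (benzyloxy)methyl goes with the lower number. As far as these compounds go, how a methyl, a benzyl or a longer alkyl chain on this nitrogen would read also remains open.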